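The compounds below may be only part of what the source reports. "The series", "measured", "known", "first", "only" and "open" are said of these compounds alone.

Measured so far:
compound 2 `CCc1nnc(SCC(=O)c2ccc(Cl)cc2)n1N1C(=O)c2ccccc2C1=O` — > 200000 nM
compound 1 `CCOC(=O)CSc1nnc(C)n1N1C(=O)c2ccccc2C1=O` — > 200000 nM

In a functional assay on A549 cells (Homo sapiens) for cytotoxicity, read by MTT assay, with a stated time of 48 h (a lower number here means a stronger inhibitor, a higher number a weaker inhibitor), compound 2 gives > 200000 nM, which is a limit of the assay and not a measured number. Compound 1 gives > 200000 nM in this assay, also a limit. Going by the values given here, every value shown so far sits at the limit of > 200000 nM in this assay, at which 2 of the 2 values shown sit, so no step between two measured compounds exists against which a structural change could be weighed.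

Compound 3 `CCOC(=O)CSc1nnc(CC)n1N1C(=O)c2ccccc2C1=O` has not yet been measured in this assay. Compared with compound 2 it carries ethoxy in place of 4-chlorophenyl on a carbonyl carbon, so the ester of compound 1 returns while the ethyl group of compound 2 on the shared core is kept. With both measured compounds at the limit, the expected step of a number no higher from compound 2 to compound 3 (the limit leaves the size open) is none beyond the usual scatter. Compound 3 is therefore estimated at 200000 nM, with a range from 100000 nM to 500000 nM, and most likely the assay will again report only a limit.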

Compound 3, half-maximal inhibitory concentration: > 200000 nM
Compound 3: no number, only a limit; the forecaster's own chance of this, stated with the estimate: 85%; the middle value lies on the limit itself.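

Compound 3 again gives only a limit of the assay, so the steps to it from compound 1 and from compound 2 cannot be read. The compounds shown leave open whether any change on the shared core gives a measurable value in this assay, since all of them sit at one value: the limit of > 200000 nM in this assay, at which 3 of the 3 values shown sit.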